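This account rests on a few compounds, and the source may have more. Where it says the series, first, only, none or still open, it means among the compounds named here.

Notes on the series around compound 1, `Fc1cccc(Nc2nccc(-c3ccccn3)n2)c1`. In a functional assay for inhibition, with Homo sapiens as the target (a lower number here means a stronger inhibitor, a higher number a weaker inhibitor), compound 1 gives 1000 nM, the higher of the two numbers obtained so far. Compound 3, `Fc1cccc(Nc2nccc(-c3ccncc3)n2)c1`, gives 700 nM in this assay, and the step is a 1.4-fold lower number from compound 1 to compound 3 (0.15 log units; within the scatter). Compound 2, `Cc1cc(C)cc(Nc2nc(C)cc(-c3ccccn3)n2)c1`, returns only a limit in this assay, > 24000 nM; this is the limit of > 24000 nM in this assay, at which 1 of the 3 values shown sits.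

Compound 4, `NS(=O)(=O)c1cccc(Nc2nccc(-c3ccccn3)n2)c1`, differs from compound 1 in one place: sulfamoyl in place of fluoro on an aromatic carbon. Going by the values given here, no measured step touches this part of the shared core; the single measured step, a 1.4-fold lower number from compound 1 to compound 3 (0.15 log units; within the scatter), exchanges pyridin-4-yl for pyridin-2-yl instead and lies within the scatter, so it gives no lead on the size or direction of a change at the aromatic carbon meta to a large group. The expected value of compound 4 therefore rests on the number for compound 1, 1000 nM, with a wide band around it. The step expected from compound 1 to compound 4 is a 1.3-fold lower number from compound 1 to compound 4 (0.10 log units; within the scatter). Compound 4 is estimated at 800 nM, between 150 nM and 4000 nM.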

Compound 4, half-maximal inhibitory concentration: 500 nM
Compound 4: middle estimate off by 1.6-fold (0.20 log units), on the high side; measured number inside the range.
By their numbers in this assay, from the lowest: compounds 4, 3 and 1 (each within the scatter of the next). At a limit, above all of these: compound 2.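

Going by these compounds alone, the exchange of fluoro for sulfamoyl gives the first measured step at the aromatic carbon meta to a large group: in this assay, a 2.0-fold lower number from compound 1 to compound 4 (0.30 log units; within the scatter). Sulfamoyl brings more heavy atoms than fluoro, along with a hydrogen-bond donor and hydrogen-bond acceptors, yet the number stays within the scatter, so this position accepts a considerably larger group in this assay without a clear shift in either direction. Nothing in the data shown accounts for the size of this step.

On these data alone, it remains open whether an amine, a carboxylic acid or a methylsulfonyl group at this carbon would also stay within the scatter of compound 1. Also open, as far as these compounds go, is whether sulfamoyl behaves the same way with pyridin-4-yl in place of pyridin-2-yl on the shared core.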